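Changing the Aryl Group on the Ring Amine Nitrogen

The compounds below may be only part of what the source reports. "The series", "measured", "known", "first", "only" and "open" are said of these compounds alone.

Compound 1 `CN(C)C(=O)c1cccnc1NCCCN1CCN(c2ccccc2O)CC1`: 63.1 nM
Compound 2 `CCCc1ccccc1N1CCN(CCCNc2ncccc2C(=O)N(C)C)CC1`: 31.6 nM

In a functional assay on aorta for antagonist activity at Alpha-1D adrenergic receptor (Rattus norvegicus) (on this read-out lower numbers stand for tighter binding and higher numbers for weaker binding), compound 1 gives 63.1 nM and compound 2 gives 31.6 nM. The step of a 2.0-fold lower number from compound 1 to compound 2 (0.30 log units; within the scatter) is the only measured one, and it lies within the scatter, so the two compounds cannot be ranked against each other. Compound 3 `COc1cc(C)ccc1N1CCN(CCCNc2ncccc2C(=O)N(C)C)CC1` has not yet been measured. It differs from compound 2 in that (2-methoxy-4-methylphenyl in place of 2-propylphenyl on an amine nitrogen in a ring). The measured step bearing on this change is the one on the same aryl group, a 2.0-fold lower number from compound 1 to compound 2 (0.30 log units; within the scatter), which was small. A second change of substituents on that aryl group is therefore expected to move this assay little, if at all beyond the scatter, in either direction. Compound 3 is estimated at 45 nM, with a range from 15 nM to 130 nM, which means an expected step of a 1.4-fold higher number from compound 2 to compound 3 (0.15 log units; within the scatter).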

Compound 3, dissociation constant: 39.8 nM
Estimate against measurement, compound 3: 1.1-fold (0.05 log units) above, and the stated range covers the measured number.
By their numbers in this assay, from the lowest: compounds 2, 3 and 1 (each within the scatter of the next).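

In this assay, replacing 2-propylphenyl with 2-methoxy-4-methylphenyl on the amine nitrogen in the ring gives a 1.3-fold higher number from compound 2 to compound 3 (0.10 log units; within the scatter), and replacing 2-hydroxyphenyl with the same group gives a 1.6-fold lower number from compound 1 to compound 3 (0.20 log units; within the scatter). All three aryl groups therefore cannot be told apart at this position, and this now holds for a group with two substituents and a hydrogen-bond acceptor, which the 2-propylphenyl group lacks, at the same count of heavy atoms. No measurement is available to explain this flat result. The compounds shown leave open whether any aryl group at this position can move the number beyond the scatter, for example one carrying a carboxylic acid or an amine. They also do not show whether a longer chain in the linker would change the picture.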